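A few compounds are considered here, and "the series" means these few. Any claim that something is new, unique, unknown or untested is made for them only; others in the source may bear on it.

Measured so far in a physicochemical assay for solubility, with a stated time of 18 h, at pH 7.4; a higher number here means a more soluble compound, a lower number a less soluble compound:
Compound 1 `COc1cccc(Oc2ccc3c(NCCCNCc4cc(F)ccc4OC)ccnc3c2)c1` gives 14500 nM.
Compound 2 `COc1ccc(F)cc1CNCCCNc1ccnc2cc(-c3ccc(F)cc3)ccc12` gives 32000 nM.
Compound 3 `COc1ccc(F)cc1CNCCCNc1ccnc2cc(Oc3cccc(N(C)C)c3)ccc12` gives 14500 nM.

Compound 3 sits level with compound 1 in this assay, and together the two give the lowest of the three numbers; compound 2 is the furthest away, a step of a 2.2-fold lower number from compound 2 to compound 3 (0.34 log units; beyond the scatter). The three compounds share one core and differ only in the group carried on one aromatic carbon of that core.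

Compound 4 `COc1ccc(F)cc1CNCCCNc1ccnc2cc(CC(C)C)ccc12` takes the next step from compound 3: isobutyl in place of 3-(dimethylamino)phenoxy on an aromatic carbon. Within the data shown here, no measured step tries a chain without a ring at this place. The steps that do bear on it show how much this position can move the number: a 2.2-fold higher number from compound 1 to compound 2 (0.34 log units; beyond the scatter), while no change at the digits printed from compound 1 to compound 3 (within the scatter). Swapping one ring-bearing group for another thus changed solubility only modestly, and never by more than a couple of steps of scatter.

On that basis compound 4 is expected to show a modest rise, a 1.7-fold higher number from compound 3 to compound 4 (0.24 log units; within the scatter), but anything within the scatter would not surprise. The estimate for compound 4 is 25000 nM, with a range from 10000 nM to 60000 nM.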

Compound 4, solubility: 4200 nM
Beside the measured number, compound 4's estimate is 6.0-fold (0.77 log units) above it; measured number below the stated range.
By their numbers in this assay, from the lowest: compound 4; then compounds 1 and 3 (each within the scatter of the next); then compound 2.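

Replacing a ring-bearing group with isobutyl, which has no ring, moves the number in this assay further than the earlier swaps between ring-bearing groups did (a 3.5-fold lower number from compound 3 to compound 4 (0.54 log units; beyond the scatter)), and the same drop appears from the other phenoxy compound (a 3.5-fold lower number from compound 1 to compound 4 (0.54 log units; beyond the scatter)). The largest step starts from the 4-fluorophenyl compound (a 7.6-fold lower number from compound 2 to compound 4 (0.88 log units; beyond the scatter)), which places compound 4 lowest of the four, and none of the three ring-bearing compounds goes against this. Among these compounds, the earlier compounds could show only that one ring-bearing group can stand in for another with a modest shift or none, whereas this result shows that a smaller chain without a ring does not hold the number at their level and that this position has a wider reach than they suggested.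

A longer chain, a cyclohexyl ring, or an isobutyl chain carrying an amine or a hydroxyl group at this place would help separate the loss of the aromatic ring from the nature of the chain itself. Nothing shown here explains why the number falls with this change.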